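The source may report more compounds than this note shows. Statements on the series, on what has been measured and on what is new or still open speak of the compounds shown alone.

Three compounds that share one core and differ in the group on the amine nitrogen have been measured in a functional assay on HL-60 cells (Homo sapiens) for inhibition, read by MTT assay, with a stated time of 72 h; on this read-out lower numbers stand for stronger inhibition and higher numbers for weaker inhibition. Compound 1 `Cc1ccc(C)c(N2CCN(C(=O)c3oc(C)nc3-c3ccccc3)CC2)c1` gives 31.3 nM, compound 2 `Cc1nc(-c2ccccc2)c(C(=O)N2CCN(c3ccccc3Cl)CC2)o1` gives 124 nM, and compound 3 `Cc1nc(-c2ccccc2)c(C(=O)N2CCN(c3cccc(C(F)(F)F)c3)CC2)o1` gives 153 nM. Compound 3 thus stands at the upper end of this small set, together with compound 2: the step of a 1.2-fold higher number from compound 2 to compound 3 (0.09 log units; within the scatter) does not separate them, whereas the step of a 4.9-fold higher number from compound 1 to compound 3 (0.69 log units; beyond the scatter) is a modest one. Compound 4 `Cc1nc(-c2ccccc2)c(C(=O)N2CCN(c3ccc(C)c(C)c3)CC2)o1` has 3,4-dimethylphenyl in place of 3-(trifluoromethyl)phenyl on an amine nitrogen in a ring. Going by the values given here, the closest guide is that same modest step, read in reverse, since compound 1 is the only measured compound with a dimethylphenyl group. The step of a 4.0-fold higher number from compound 1 to compound 2 (0.60 log units; beyond the scatter) is of similar size. The methyl groups of compound 4 are placed differently, however, so only part of that gain is expected to carry over. The expected step is a 2.2-fold lower number from compound 3 to compound 4 (0.34 log units; beyond the scatter), modest and towards a lower number. For compound 4 the estimated value is 70 nM, within an expected range of 28 nM to 170 nM.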

Compound 4, half-maximal inhibitory concentration: 43 nM
Compound 4: the middle estimate sits 1.6-fold (0.21 log units) above what was measured; measured number inside the range.
By their numbers in this assay, from the lowest: compounds 1 and 4 (each within the scatter of the next); then compounds 2 and 3 (each within the scatter of the next).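

In this assay, 3,4-dimethylphenyl on the amine nitrogen stands clearly apart from two other groups at this position, with a 3.6-fold lower number from compound 3 to compound 4 (0.55 log units; beyond the scatter) against 3-(trifluoromethyl)phenyl and a 2.9-fold lower number from compound 2 to compound 4 (0.46 log units; beyond the scatter) against 2-chlorophenyl. Against 2,5-dimethylphenyl, the step is a 1.4-fold higher number from compound 1 to compound 4 (0.14 log units; within the scatter), so among these compounds the lower numbers are no longer confined to a single arrangement of the two methyl groups, although this rests on compounds 1 and 4 alone. Nothing given here explains these differences.

The compounds shown leave open whether a phenyl ring bearing only one methyl group, or a methoxy group or an amine, would match the dimethylphenyl compounds. They also leave open whether these differences would persist with a longer chain in place of the methyl group on the shared core.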